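The source may hold more compounds than are shown below. What is called first, only, known or untested is meant among the compounds shown, and "the series" means these compounds.

The measured compounds so far:

Compound 1, `COc1ccc(C(=O)O[C@H]2CC(C)=C[C@H](OC(C)=O)[C@@]3(C)[C@@H](OC(C)=O)C[C@@](O)(C(C)C)[C@H]23)cc1`, in a functional assay on A549 cells (Homo sapiens) for cytotoxicity, read by MTT assay, with a stated time of 72 h (on this read-out higher numbers stand for weaker inhibition and lower numbers for stronger inhibition), compound 1 gives 23300 nM.
Compound 2, `CC1=C[C@H](OC(=O)c2ccc(O)cc2)[C@@H]2[C@](C)(CC[C@@]2(O)C(C)C)CC1=O`, in this assay compound 2 gives 14500 nM.

Compound 2 has the lower of the two numbers, but the gap between compound 2 and compound 1 lies within the scatter of repeated measurements, so nothing can be said about an order between them. For the measured compounds named here, no step between measured compounds that differ in one place is available, so there is no measured guide for the change now taken.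

The account turns to compound 3, `COc1ccc(C(=O)O[C@H]2C=C(C)C(=O)C[C@@]3(C)CC[C@@](O)(C(C)C)[C@H]23)cc1`, which is not yet measured in this assay. Compared with compound 2 it differs by methyl in place of hydrogen on an oxygen on an aromatic ring. Going by the values given here, the core also differs from that of compound 2, so the step rests on no measured pair. Compound 1, which carries the same methoxy group, gives 23300 nM, a number within the scatter of compound 2, so no shift beyond the scatter is expected for the change from hydroxy to methoxy.

The step from compound 2 to compound 3 is expected to be a 1.2-fold higher number from compound 2 to compound 3 (0.09 log units; within the scatter). Compound 3 is estimated at 18000 nM, with a range from 7000 nM to 45000 nM.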

Compound 3, half-maximal inhibitory concentration: 31800 nM
For compound 3 the middle estimate is 1.8-fold (0.25 log units) below the measured one, within the range that was stated.
By their numbers in this assay, from the lowest: compounds 2, 1 and 3 (each within the scatter of the next, the first and the last beyond it).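

For the compounds shown here, on the shared core, the change from 4-hydroxyphenyl to 4-methoxyphenyl gives a 2.2-fold higher number from compound 2 to compound 3 (0.34 log units; beyond the scatter) in this assay and is the first change in this set that can be read at a single place. Methyl in place of hydrogen on an oxygen on an aromatic ring therefore shifts the read-out modestly towards weaker inhibition, and within this pair the free hydroxy goes with the lower number. Nothing measured here accounts for the shift, which stands as an observation from this one pair.

On these data alone, whether the same step holds on the core of compound 1 stays open, since that compound has no partner differing from it in one place. Also open, as far as these compounds go, is how the read-out would respond to a longer chain on this oxygen, such as ethoxy or benzyloxy, or to an amine or a carboxylic acid on the aromatic ring in place of the hydroxy.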